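Adding a Second Chlorine to a Phenylurea Series

This account rests on a few compounds, and the source may have more. Where it says the series, first, only, none or still open, it means among the compounds named here.

Of the compounds shown here, three of a small urea series have been measured. Compound 1 `C[C@H](NC(=O)Nc1ccccc1Cl)c1ccccc1` carries one chloro group on its aryl ring, and compound 3 `C[C@H](NC(=O)Nc1c(Cl)cccc1Cl)c1ccccc1` is its close relative: the change from compound 1 to compound 3 is chloro in place of hydrogen on an aromatic carbon. Compound 2 `C[C@@H](NC(=O)Nc1cccc(Cl)c1)c1ccccc1` has the same atoms as compound 1 joined differently; the difference between the two cores is not broken down here. The fourth member, compound 4 `C[C@@H](NC(=O)Nc1ccc(Cl)c(Cl)c1)c1ccccc1`, has not yet been measured.

In an ADME assay on the whole organism with Oryza sativa as the target, tested at 0.1 uM (a higher number here means a weaker effect of the compound at the concentration tested, a lower number a stronger effect), compound 1 gives 99%, compound 3 gives 100%, and compound 2 gives 97%. Within the data shown here, the one counted step between measured compounds, a number 1 percentage points higher from compound 1 to compound 3 (within the scatter), shows that the extra chloro group left the read-out essentially where it was. The values of compound 2 and compound 1, like those of compound 2 and compound 3, also lie close together.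

Among the measured compounds shown here, the change from compound 2 to compound 4 is chloro in place of hydrogen on an aromatic carbon, the same kind of change as the one from compound 1 to compound 3, though the surroundings differ: in compound 3 the new chloro group sits ortho to a large group and meta to a chloro group, whereas in compound 4 it sits ortho to a chloro group and para to a large group. Because the step of a number 1 percentage points higher from compound 1 to compound 3 (within the scatter) was small, the step from compound 2 to compound 4 is expected to be small as well, about a number 1 percentage points higher from compound 2 to compound 4 (within the scatter). Compound 4 is therefore estimated to give 98% in this assay, expected to fall between 90% and 100%.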

Compound 4, a percentage reported as activity, at one concentration (the size of the read-out at that concentration, not a potency): 98%
The estimate for compound 4 equals the measured number at the digits printed; the range from low to high includes it.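

In this assay the added chloro group gives a number 1 percentage points higher from compound 2 to compound 4 (within the scatter). Set beside the earlier step, the same change behaves alike on the two cores: the same change on two cores in this assay, a number 1 percentage points higher (within the scatter) from compound 1 to compound 3 and a number 1 percentage points higher (within the scatter) from compound 2 to compound 4, 0 percentage points apart, within the scatter of two such steps

This shows that, for these two pairs, the added chloro group leaves the read-out essentially where it was, even though the new group has different surroundings on the ring in each pair. It does not show that the change would stay this small on a third core, and two small steps do not amount to a rule for the whole series.

The compounds shown carry only chloro groups on the aryl ring, so it remains open whether a methoxy group, a nitrile or a trifluoromethyl group there would move the read-out beyond the scatter. Also open, on these data alone, is what would happen with a longer chain in place of the methyl group, or with an amine or a carboxylic acid on the unsubstituted phenyl ring.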